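The source may hold more compounds than are shown below. What is called first, only, known or untested is meant among the compounds shown, and "the series" means these compounds.

Working notes on the series. In an ADME assay on HEK293 cells (Homo sapiens) for inhibition, read by MTT assay, with a stated time of 3 days (a lower number here means a stronger inhibitor, a higher number a weaker inhibitor), compound 1 `COc1cccc(/C=C/CCCOc2cc(/C=C\c3cc(OC)c(OC)c(OC)c3)ccc2OC)c1` gives 39000 nM, compound 2 `COc1ccc(/C=C/CCCOc2cc(/C=C\c3cc(OC)c(OC)c(OC)c3)ccc2OC)cc1` gives 88000 nM and compound 3 `COc1ccc(/C=C\c2cc(OC)c(OC)c(OC)c2)cc1OCCC/C=C/c1ccc(Cl)cc1` gives 111000 nM. Compound 3 carries a higher number than compound 1, as a 2.8-fold higher number from compound 1 to compound 3 (0.45 log units; beyond the scatter) shows. Against compound 2 the picture differs: a 1.3-fold higher number from compound 2 to compound 3 (0.10 log units; within the scatter) stays within the scatter, so no order is drawn between those two.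

The next entry is compound 4 `COc1ccc(/C=C\c2cc(OC)c(OC)c(OC)c2)cc1OCCC/C=C/c1ccc(Br)cc1`, not yet measured. It differs from compound 3 by bromo in place of chloro on an aromatic carbon, which is bromo in place of chloro on an aromatic carbon, para to a large group. Among the compounds with values here, no measured step exchanges one halogen for another, so there is no direct precedent. The closest evidence is the other replacement on that aromatic carbon, chloro in place of methoxy, where a 1.3-fold higher number from compound 2 to compound 3 (0.10 log units; within the scatter) is again the step. The modest changes, a 2.3-fold higher number from compound 1 to compound 2 (0.35 log units; beyond the scatter) and a 2.8-fold higher number from compound 1 to compound 3 (0.45 log units; beyond the scatter), both leave 3-methoxyphenyl, a change that compound 4 does not make, so they bear on it less.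

No shift beyond the scatter is expected in this assay, in either direction. The expected step is a 1.0-fold higher number from compound 3 to compound 4 (0.02 log units; within the scatter). For compound 4 the estimate is 115000 nM, with an expected range from 60000 nM to 210000 nM.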

Compound 4, half-maximal inhibitory concentration: 55000 nM
Estimate against measurement, compound 4: 2.1-fold (0.32 log units) above; measured number below the stated range.
By their numbers in this assay, from the lowest: compounds 1, 4, 2 and 3 (each within the scatter of the next, the first and the last beyond it).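

In this assay, within the data shown here, this is the first exchange of one halogen for another on this aromatic carbon, and a 2.0-fold lower number from compound 3 to compound 4 (0.30 log units; within the scatter) does not separate bromo from chloro; a 1.6-fold lower number from compound 2 to compound 4 (0.20 log units; within the scatter) likewise does not separate bromo from methoxy, so methoxy, chloro and bromo at this place, para to a large group, cannot be ordered. Compound 4 also changes the reading of compound 1: 4-methoxyphenyl and 4-chlorophenyl each stood beyond the scatter from 3-methoxyphenyl, but a 1.4-fold higher number from compound 1 to compound 4 (0.15 log units; within the scatter) does not, so compound 4 goes against any claim that compound 1 stands apart from all three 4-substituted phenyl compounds. No measurement on hand accounts for any of these steps.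

Still open, on these data alone, is whether any group on this aromatic carbon can move the number beyond the scatter, as methoxy, chloro and bromo leave that untested and an amine or a carboxylic acid there would be a sharper probe. Also open, as far as these compounds go, is whether the gap between compound 1 and compounds 2 and 3 holds up with a longer chain in place of the present one, or with a nitrile on the terminal phenyl ring.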